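A few compounds are considered here, and "the series" means these few. Any claim that something is new, unique, unknown or untested is made for them only; others in the source may bear on it.

Three compounds have so far been measured in a functional assay on A549 cells (Homo sapiens) for antiproliferative activity, read by MTT assay, with a stated time of 24 h; on this read-out lower numbers stand for stronger inhibition and higher numbers for weaker inhibition:

Compound 1 `COc1cc(-c2cc(/C=C/C(=O)c3ccc(C)c(C)c3)nc3cc(-c4ccccc4)nn23)cc(OC)c1OC` gives 10600 nM.
Compound 2 `COc1ccc(-c2cc(/C=C/C(=O)c3ccccc3)nc3cc(-c4ccccc4)nn23)cc1OC` gives 10700 nM.
Compound 3 `COc1ccc(-c2cc(C(=O)/C=C/c3ccccc3)nc3cc(-c4ccccc4)nn23)cc1OC` gives 18600 nM.

Compound 3 carries the highest of the three numbers, but this says little: the step of a 1.7-fold higher number from compound 2 to compound 3 (0.24 log units; within the scatter) lies within the scatter, and the gap between compound 1 and compound 3 is likewise within the scatter, so none of the three can be called weaker or stronger than another.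

The next compound, compound 4 `COc1ccc(-c2cc(/C=C/C(=O)c3ccc(C)c(C)c3)nc3cc(-c4ccccc4)nn23)cc1OC`, differs from compound 3 in one place: 2-((3,4-dimethylphenyl)carbonyl)ethenyl in place of (2-phenylethenyl)carbonyl on an aromatic carbon. This change does two things at once. It turns the linker back into the form found in compound 2, and it adds two methyl groups to the outer ring, as in compound 1. Among the compounds with values here, the only measured step that touches this change is a 1.7-fold higher number from compound 2 to compound 3 (0.24 log units; within the scatter), the reversal of the linker, and it stayed within the scatter. Within the data shown here, for the two methyl groups no direct step exists; compound 1 and compound 2, which differ from compound 4 in one place each, sit close together. A shift of a 1.7-fold lower number from compound 3 to compound 4 (0.23 log units; within the scatter) is therefore expected, essentially a return to the level of compound 2. Compound 4 is estimated at 11000 nM, within a range from 5000 nM to 25000 nM.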

Compound 4, half-maximal inhibitory concentration: 9300 nM
For compound 4 the middle estimate is 1.2-fold (0.07 log units) above the measured one; low and high end bracket the measured number.
By their numbers in this assay, from the lowest: compounds 4, 1, 2 and 3 (each within the scatter of the next).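

In this assay, within the data shown here, the new compound gives the first direct look at the two methyl groups of the 3,4-dimethylphenyl group on the carbonyl carbon, and the step of a 1.2-fold lower number from compound 2 to compound 4 (0.06 log units; within the scatter) shows no difference that can be read at this level of activity. Two further comparisons also stay within the scatter: removing one methoxy group from the aromatic ring, with hydrogen in its place, gives a 1.1-fold lower number from compound 1 to compound 4 (0.06 log units; within the scatter) and exchanging the whole (2-phenylethenyl)carbonyl group for 2-((3,4-dimethylphenyl)carbonyl)ethenyl gives a 2.0-fold lower number from compound 3 to compound 4 (0.30 log units; within the scatter) even though that exchange alters both the linker and the outer ring. So all four compounds sit at one level, these changes do not separate them, and no further data are available that could explain this.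

The only groups shown on the outer rings are methyl and methoxy, so it remains open whether an amine or a carboxylic acid there would move the number beyond the scatter. From the compounds shown here alone, it is also open whether a longer chain between the core and the outer ring would do so, and whether the two methyl groups would matter with the linker of compound 3.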